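This account rests on a few compounds, and the source may have more. Where it says the series, first, only, none or still open, it means among the compounds named here.

In a functional assay on MCF7 cells (Homo sapiens) for cytotoxicity (on this read-out lower numbers stand for stronger inhibition and higher numbers for weaker inhibition), compound 1 (`COc1ccc(Cn2cc(/C=N\NC(=O)c3c[nH]c4ccc(Br)cc34)c3cc(OC)ccc32)cc1`) gives 3100 nM, while compound 2 (`COc1ccc2c(c1)c(/C=N\NC(=O)c1c[nH]c3ccc(Br)cc13)cn2Cc1ccc(Cl)cc1`) gives 29100 nM, the higher of the two numbers. Compound 3 (`COc1ccc2c(c1)c(/C=N\NC(=O)c1c[nH]c3ccccc13)cn2Cc1ccc(Cl)cc1`) differs from compound 2 by hydrogen in place of bromo on an aromatic carbon. Within the data shown here, the only measured step, a 9.4-fold higher number from compound 1 to compound 2 (0.97 log units; beyond the scatter), is a chloro-for-methoxy exchange at another place, so no measurement tests the loss of bromo. With no direction supported, the estimated change is a 1.0-fold higher number from compound 2 to compound 3 (0.01 log units; within the scatter), with no shift beyond the scatter expected. For compound 3, the expected value is 30000 nM, within an estimated range of 10000 nM to 85000 nM.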

Compound 3, half-maximal inhibitory concentration: 8700 nM
For compound 3 the middle estimate is 3.4-fold (0.54 log units) above the measured one; measured number outside the range, below it.
By their numbers in this assay, from the lowest: compound 1; then compound 3; then compound 2.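

In this assay, the 5-bromo-1H-indol-3-yl to 1H-indol-3-yl change gives a 3.3-fold lower number from compound 2 to compound 3 (0.52 log units; beyond the scatter) and so shows that this position on the six-membered aromatic ring affects the read-out. With the chloro group in place, the bromo is not needed for the lower number, as hydrogen alone does better here. No available evidence accounts for this shift. As far as these compounds go, whether the loss of bromo acts the same way with the methoxy group of compound 1 remains open. So does how a fluoro, a methyl or an amine would compare with hydrogen at this position.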